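Adding a Second Methoxy to a Sulfonamide-Linked Core

The source may hold more compounds than are shown below. What is called first, only, known or untested is meant among the compounds shown, and "the series" means these compounds.

Three compounds have been measured in a functional assay on A549 cells (Homo sapiens) for antiproliferative activity, read by MTT assay, with a stated time of 72 h; a higher number here means a weaker inhibitor, a lower number a stronger inhibitor:

compound 1, `CN(C(=O)c1ccccc1)c1ccc2[nH]c(-c3n[nH]c4ccccc34)cc2n1`, 13800 nM
compound 2, `COc1ccc(C(=O)N(C)c2ccc3[nH]c(-c4n[nH]c5ccccc45)cc3n2)cc1`, 14600 nM
compound 3, `COc1ccc(S(=O)(=O)N(C)c2ccc3[nH]c(-c4n[nH]c5ccccc45)cc3n2)cc1`, 24300 nM

Compound 1 and compound 2 share a core and differ in one place: methoxy in place of hydrogen on an aromatic carbon. This change gave a 1.1-fold higher number from compound 1 to compound 2 (0.02 log units; within the scatter), so the two values cannot be told apart. Compound 3 carries a different linker to the core; the difference between the core of compound 1 and that of compound 3 is not broken down here, and their two values also lie within the usual scatter of each other.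

Compound 4, `COc1ccc(S(=O)(=O)N(C)c2ccc3[nH]c(-c4n[nH]c5ccccc45)cc3n2)cc1OC`, has not been measured. It differs from compound 3 in one place: methoxy in place of hydrogen on an aromatic carbon. This is the same kind of change as from compound 1 to compound 2, but not the same: there the new group sat para to a large group, while here it sits ortho to a methoxy group and meta to a large group.

Going by the values given here, the expectation for compound 4 rests on the single earlier example, where the step was a 1.1-fold higher number from compound 1 to compound 2 (0.02 log units; within the scatter) and left the value essentially unchanged. The step from compound 3 to compound 4 is therefore expected to be small, a 1.1-fold higher number from compound 3 to compound 4 (0.03 log units; within the scatter), with added uncertainty from the different surroundings of the new group. Compound 4 is expected to give about 26000 nM, most likely between 12000 nM and 55000 nM.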

Compound 4, half-maximal inhibitory concentration: > 50000 nM
Compound 4 was reported as a limit; the forecaster's own chance of this, stated with the estimate: 10%; middle value at least 1.9-fold (0.28 log units) from the limit.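

In this assay compound 4 is reported as > 50000 nM, which is a limit of the assay and not a number. Going from 4-methoxyphenyl to 3,4-dimethoxyphenyl on the sulfonamide-linked compounds gave an at least 2.0-fold higher number from compound 3 to compound 4 (0.31 log units; beyond the scatter), a step beyond the scatter, whereas the methoxy step on the amide-linked compounds gave a 1.1-fold higher number from compound 1 to compound 2 (0.02 log units; within the scatter), which lies within it. This does not show that the same change behaves differently on the two cores, nor that it carries over unchanged, because only a lower bound is known for the second step: the same change on two cores in this assay, a 1.1-fold higher number (0.02 log units; within the scatter) from compound 1 to compound 2 and an at least 2.0-fold higher number (0.31 log units; beyond the scatter) from compound 3 to compound 4; the limit leaves it open whether they differ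

The compounds shown leave open how large the step to compound 4 really is, and whether a 3,4-dimethoxyphenyl group on the amide linker of compound 2 would also raise the number beyond the scatter. They also leave open whether a different group at that same place on the ring, such as a fluorine, a hydroxyl or an amine, would give a value that could be read as a number in this assay rather than as a limit.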